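Trading 4-Chlorophenyl for Cyclobutyl in Compound 4

A few compounds are considered here, and "the series" means these few. Any claim that something is new, unique, unknown or untested is made for them only; others in the source may bear on it.

Three measured compounds share one core and differ only in the group on a saturated chain carbon bound to an amine nitrogen in a ring. In a functional assay on the whole organism for antagonist activity, with Mus musculus as the target (a lower number here means that less compound is needed, a higher number that more compound is needed for the effect), compound 2 `COc1cc(N)c(Cl)cc1NC(=O)C1CCN(Cc2ccc(Cl)cc2)CC1` gives 1.2 mg/kg, the lowest of the two numbers in hand. Compound 1 `COc1cc(N)c(Cl)cc1NC(=O)C1CCN(CC2CCCCC2)CC1` gives 2.9 mg/kg in this assay. For compound 3 `CCCCCCN1CCC(C(=O)Nc2cc(Cl)c(N)cc2OC)CC1` this assay reports only a limit, > 10 mg/kg, and not a number. The step of a 2.4-fold lower number from compound 1 to compound 2 (0.38 log units; beyond the scatter) shows that the saturated ring needed more compound than the chlorinated aromatic ring, and the step of an at least 8.3-fold higher number from compound 2 to compound 3 (0.92 log units; beyond the scatter) points the same way, its full size hidden by the limit of > 10 mg/kg in this assay, at which 1 of the 3 values shown sits.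

Compound 4 `COc1cc(N)c(Cl)cc1NC(=O)C1CCN(CC2CCC2)CC1` has not yet been measured. It differs from compound 2 by cyclobutyl in place of 4-chlorophenyl on a saturated chain carbon bound to an amine nitrogen in a ring. Both known moves away from 4-chlorophenyl, the reverse of a 2.4-fold lower number from compound 1 to compound 2 (0.38 log units; beyond the scatter) and the step of an at least 8.3-fold higher number from compound 2 to compound 3 (0.92 log units; beyond the scatter), raised the number, so a rise is expected here as well. Cyclobutyl is a saturated ring like cyclohexyl, so the expected step is a 4.2-fold higher number from compound 2 to compound 4 (0.62 log units; beyond the scatter), a modest rise rather than the larger one seen with pentyl. Compound 4 is therefore estimated at 5 mg/kg in this assay, with a likely range from 2 mg/kg to 12 mg/kg.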

Compound 4, dose for half-maximal effect: > 10 mg/kg
Compound 4: a limit, no number; the forecaster's own chance of this, stated with the estimate: 25%; middle value at least 2.0-fold (0.30 log units) away from the limit.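

Ring size matters at this position, since two saturated rings on the same chain carbon do not give the same result. In this assay, the change is an at least 3.4-fold higher number from compound 1 to compound 4 (0.53 log units; beyond the scatter), so a saturated ring alone does not keep compound 4 level with compound 1, and cyclobutyl cannot stand in for cyclohexyl. Measured against the aromatic group, the change is an at least 8.3-fold higher number from compound 2 to compound 4 (0.92 log units; beyond the scatter), which makes cyclobutyl the third replacement for 4-chlorophenyl to raise the number, after the cyclohexyl of compound 1 and the pentyl of compound 3. The values of compound 3 and compound 4 are both limits, so the step from one to the other cannot be read and pentyl and cyclobutyl cannot be put in order: the limit of > 10 mg/kg in this assay, at which 2 of the 4 values shown sit.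

The compounds shown do not separate the chlorine from the aromatic ring in compound 2, a question that a plain phenyl group on the same carbon would address. They also leave open how the number changes with ring size from cyclobutyl up to cyclohexyl, where a cyclopentyl group would fill the gap.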